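A few compounds are considered here, and "the series" means these few. Any claim that something is new, unique, unknown or untested is made for them only; others in the source may bear on it.

Measured compounds:
compound 1, `Cc1cccc(NC(=O)CN2CCC(c3nccs3)CC2)c1`, 1 nM
compound 2, `C=Cc1cccc(C(=O)NCN2CCC(c3cccc[n+]3[O-])CC2)c1`, 68 nM
compound 3, `Cc1ccc([N+](=O)[O-])cc1NC(=O)CN1CCC(c2cccc[n+]2[O-])CC1`, 134 nM

These three compounds were tested in a functional assay on HEK293 cells for agonist activity at D(4) dopamine receptor (Homo sapiens), read by FLIPR; a lower number here means that less compound is needed, a higher number that more compound is needed for the effect. Compound 1 gives the lowest of the three numbers, 1 nM; the closest to it is compound 2 with 68 nM, and furthest away is compound 3 with 134 nM, both gaps lying beyond the usual scatter of repeated measurements. Compound 4, `Cc1cccc(NC(=O)CN2CCC(c3ccccc3)CC2)c1`, has not yet been measured in this assay. It differs from compound 1 in one place: phenyl in place of 1,3-thiazol-2-yl on a saturated ring carbon. The group that leaves carries two hydrogen-bond acceptors, the group that enters carries none, and the change sits on a saturated ring carbon of the shared core, three ring bonds from the ring nitrogen. Within the data shown here, no pair of measured compounds differs in exactly this way, so nothing here shows directly how large such a change is. With compound 1 already at the low end of what has been seen, the expectation is a modest rise in the number, a step from compound 1 to compound 4 of about a 5.0-fold higher number from compound 1 to compound 4 (0.70 log units; beyond the scatter), which may or may not exceed the scatter. For compound 4 the estimated value in this assay is 5 nM, expected to fall between 1 nM and 30 nM.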

Compound 4, half-maximal effective concentration: 170 nM
The estimate for compound 4 lay 34-fold (1.53 log units) below the measured number, and the stated range ends below it.
By their numbers in this assay, from the lowest: compound 1; then compounds 2, 3 and 4 (each within the scatter of the next, the first and the last beyond it).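

In this assay, placing phenyl instead of 1,3-thiazol-2-yl on this saturated ring carbon, three ring bonds from the ring nitrogen, gives a 170-fold higher number from compound 1 to compound 4 (2.23 log units; beyond the scatter), a large step. This first direct comparison at the position shows that the number depends strongly on which aromatic ring sits there, even though neither ring carries a net charge. The change exchanges a ring with hydrogen-bond acceptors for one without, but nothing measured here explains why the step is so large.

The compounds shown leave open whether the nitrogen or the sulfur of the 1,3-thiazol-2-yl matters more, which 1,3-oxazol-2-yl, with oxygen in place of the sulfur, or pyridin-2-yl on the same core could help to test. They also leave open how a non-aromatic group, such as an amine, would behave on this carbon.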